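Adding Chloro Beside a Nitro Group on the Anilide Ring

A few compounds are considered here, and "the series" means these few. Any claim that something is new, unique, unknown or untested is made for them only; others in the source may bear on it.

Compound 1 `O=C(Nc1ccc(OC(F)(F)F)cc1)c1cc(F)ccc1O`, compound 2 `O=C(Nc1ccc(OC(F)(F)F)c(Cl)c1)c1cc(F)ccc1O` and compound 3 `O=C(Nc1ccc([N+](=O)[O-])cc1)c1cc(F)ccc1O` share one core, and compound 4 `O=C(Nc1ccc([N+](=O)[O-])cc1Cl)c1cc(F)ccc1O` has not been measured yet. In a functional assay on HL-60 cells (Homo sapiens) for cytotoxicity, read by luminescence and CellTiter-Glo, with a stated time of 3 days (on this read-out higher numbers stand for weaker inhibition and lower numbers for stronger inhibition), compound 1 gives 850 nM, compound 2 gives 550 nM, and compound 3 gives 520 nM. All three numbers sit close together in this assay.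

The step chloro in place of hydrogen on an aromatic carbon gave a 1.5-fold lower number from compound 1 to compound 2 (0.19 log units; within the scatter). The core of compound 3 differs from that of compound 1 through (nitro in place of trifluoromethoxy on an aromatic carbon). The change from compound 3 to compound 4 is chloro in place of hydrogen on an aromatic carbon. In compound 2 the chloro sits ortho to a trifluoromethoxy group and meta to a large group, whereas in compound 4 it sits ortho to a large group and meta to a nitro group, so this is the same kind of change, not the same one.

Because the earlier chloro step gave a 1.5-fold lower number from compound 1 to compound 2 (0.19 log units; within the scatter), a similarly small step is expected here, a 1.4-fold lower number from compound 3 to compound 4 (0.14 log units; within the scatter), in this assay. Compound 4 is therefore expected to give 380 nM in this assay, most likely between 180 nM and 800 nM.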

Compound 4, half-maximal inhibitory concentration: 280 nM
For compound 4 the middle estimate is 1.4-fold (0.13 log units) above the measured one; the range from low to high includes it.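

In this assay, chloro in place of hydrogen on an aromatic carbon gives a 1.9-fold lower number from compound 3 to compound 4 (0.27 log units; within the scatter), a small step like the earlier one on the core of compound 1. Set side by side, the two steps agree as closely as repeated measurements can show: the same change on two cores in this assay, a 1.5-fold lower number (0.19 log units; within the scatter) from compound 1 to compound 2 and a 1.9-fold lower number (0.27 log units; within the scatter) from compound 3 to compound 4, 1.2-fold (0.08 log units) apart, within the scatter of two such steps This shows that the change carried over to a second core without a clear difference in the size of its step, but each step lies within the scatter, so neither one shows on its own that chloro alters the number, and two pairs do not make a rule for the series, especially as the chloro in compound 4 sits ortho to a large group and meta to a nitro group, a different place from the one it holds in compound 2.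

The compounds shown leave open whether a bromo, a methyl or an amine in place of that hydrogen would give a step of similar size. Going by these compounds, it also remains open whether chloro would behave alike on a core carrying a nitrile in place of the nitro group.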